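This account rests on a few compounds, and the source may have more. Where it says the series, first, only, none or still open, it means among the compounds named here.

Measured compounds (read-out from an in vitro ADME assay on microsomes from liver (Homo sapiens) for metabolic stability, using NADPH; on this read-out lower numbers stand for slow clearance and higher numbers for fast clearance)

- Compound 1 `COc1ccc(OC(F)(F)F)cc1Cn1c(C(=O)NCC(C)(C)CO)cc2cc(C#N)ccc21` (69 mL.min-1.g-1)
- Compound 2 `CCOc1ccc(OC(F)(F)F)cc1Cn1c(C(=O)NCC(C)(C)CO)cc2cc(C#N)ccc21` (103 mL.min-1.g-1)
- Compound 3 `COc1ccc(OC(F)(F)F)cc1Cn1c(C(=O)NCC2(CO)CC2)cc2cc(C#N)ccc21` (139 mL.min-1.g-1)

Compound 3 stands within the scatter of both compound 1 and compound 2, so the three values do not separate.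

The next step leads to compound 4 `COc1ccc(C(F)(F)F)cc1Cn1c(C(=O)NCC2(CO)CC2)cc2cc(C#N)ccc21`, which has trifluoromethyl in place of trifluoromethoxy on an aromatic carbon. The group sits para to a methoxy group. Within the data shown here, no measured pair covers this exchange, so the data give no direct guide to it.

Among the measured compounds shown here, two measured steps bear on it only as a rough scale for single changes elsewhere in the structure. One is methyl in place of hydrogen on a saturated chain carbon bound to an oxygen on an aromatic ring (a 1.5-fold higher number from compound 1 to compound 2 (0.17 log units; within the scatter)). The other is 1-(hydroxymethyl)cyclopropyl in place of 1-(hydroxymethyl)-1-methylethyl on a saturated chain carbon bound to an amide-type nitrogen (a 2.0-fold higher number from compound 1 to compound 3 (0.30 log units; within the scatter)). Both lie within the scatter.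

The expectation therefore starts from compound 3 (139 mL.min-1.g-1) and allows no step beyond the scatter in this assay, with no firm direction. The expected step is small (a 1.2-fold lower number from compound 3 to compound 4 (0.08 log units; within the scatter)).

Compound 4 is estimated at 115 mL.min-1.g-1 with 60 mL.min-1.g-1 to 220 mL.min-1.g-1 as the expected range.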

Compound 4, intrinsic clearance in microsomes: 155 mL.min-1.g-1
Beside the measured number, compound 4's estimate is 1.3-fold (0.13 log units) below it, and the stated range covers the measured number.
By their numbers in this assay, from the lowest: compounds 1, 2, 3 and 4 (each within the scatter of the next, the first and the last beyond it).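

In this assay, trifluoromethyl in place of trifluoromethoxy on the aromatic carbon para to a methoxy group gives a 1.1-fold higher number from compound 3 to compound 4 (0.05 log units; within the scatter). This is the only pair shown that changes this position, and it shows that the oxygen joining the fluorinated carbon to the ring can be removed, with the 1-(hydroxymethyl)cyclopropyl amide and the rest of compound 3 in place, without a step beyond the scatter in intrinsic clearance in microsomes. No supporting measurement is available to explain why the two groups read alike here.

On these data alone, it remains open whether the same exchange reads alike with the 1-(hydroxymethyl)-1-methylethyl group of compound 1 or the ethoxy group of compound 2, since one pair cannot show whether the result carries over to other parts of the series. As far as these compounds go, it is also open whether a group of another kind at this position, such as a chlorine atom, a primary amine or a carboxylic acid, would give a step beyond the scatter in this assay.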